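Series notes: amine swap on the thiocarbonyl carbon

The source may report more compounds than this note shows. Statements on the series, on what has been measured and on what is new or still open speak of the compounds shown alone.

Measured so far:
compound 1 `COc1ccc2oc(CSC(=S)N3CCOCC3)cc(=O)c2c1`: 3000 nM
compound 2 `O=c1c(CSC(=S)N2CCOCC2)coc2cc(Cl)ccc12`: 900 nM
compound 3 `COc1ccc2oc(CSC(=S)N3CCCCC3)cc(=O)c2c1`: 1500 nM

In a functional assay on HEp-2 cells (Homo sapiens) for antiproliferative activity, read by MTT assay, with a stated time of 72 h (on this read-out higher numbers stand for weaker inhibition and lower numbers for stronger inhibition), compound 1 gives 3000 nM, compound 3 gives 1500 nM and compound 2 gives 900 nM. Compound 1 and compound 3 share one core and differ only by piperidin-1-yl in place of morpholin-4-yl on a thiocarbonyl carbon; that change gave a 2.0-fold lower number from compound 1 to compound 3 (0.30 log units; within the scatter). The core of compound 2 is another one; the difference between the two cores is not broken down here. Compound 4 `O=c1c(CSC(=S)N2CCCCC2)coc2cc(Cl)ccc12` is not yet measured in this assay; it carries the same change on the core of compound 2, namely (piperidin-1-yl in place of morpholin-4-yl on a thiocarbonyl carbon). For the measured compounds named here, the expected step is a 2.0-fold lower number from compound 2 to compound 4 (0.30 log units; within the scatter), resting on the single earlier instance a 2.0-fold lower number from compound 1 to compound 3 (0.30 log units; within the scatter) from compound 1 to compound 3. In this assay compound 4 is expected at 450 nM, plausibly between 200 nM and 1300 nM.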

Compound 4, half-maximal inhibitory concentration: 280 nM
Compound 4: middle estimate off by 1.6-fold (0.21 log units), on the high side, within the range that was stated.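

In this assay, piperidin-1-yl in place of morpholin-4-yl on a thiocarbonyl carbon gave a 3.2-fold lower number from compound 2 to compound 4 (0.51 log units; beyond the scatter). The same change has now been read on two cores, and the two steps do not differ beyond the scatter: the same change on two cores in this assay, a 2.0-fold lower number (0.30 log units; within the scatter) from compound 1 to compound 3 and a 3.2-fold lower number (0.51 log units; beyond the scatter) from compound 2 to compound 4, 1.6-fold (0.21 log units) apart, within the scatter of two such steps. For the compounds shown here, this supports carrying the change between these two cores, with only the step on the core of compound 2 lying beyond the scatter, but two pairs say nothing about a further core or about why the step arises.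

Still open, on these data alone, is whether other amines on the thiocarbonyl carbon, such as pyrrolidin-1-yl, diethylamino or 4-methylpiperazin-1-yl, would track piperidin-1-yl on both cores. A third core carrying the same pair of amines would test the transfer further.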